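Bromo to methoxy on the pendant ring of compound 1

The source may report more compounds than this note shows. Statements on the series, on what has been measured and on what is new or still open speak of the compounds shown alone.

Measured compounds:
compound 1, `C#CCNC1CCc2c(SCCc3cccc(Br)c3)cccc21`, 30500 nM
compound 2, `C#CCNC1CCc2c(SCc3cccc(OC)c3)cccc21`, 3190 nM
compound 3, `C#CCNC1CCc2c(SCc3ccc(C(F)(F)F)cc3)cccc21`, 9680 nM

Of the compounds shown here, three sharing the same core have been tested in an assay on isolated protein for inhibition of Amine oxidase [flavin-containing] B (Homo sapiens); on this read-out higher numbers stand for weaker inhibition and lower numbers for stronger inhibition. Compound 1 gives 30500 nM, the highest number of the three. Its nearest neighbour on the scale is compound 3 with 9680 nM, and the furthest is compound 2 with 3190 nM; both of those gaps lie beyond the usual scatter. Among the compounds with values here, compound 2 also carries a methoxy group on its pendant ring, though on a shorter linker, so no single step among the measured compounds isolates the bromo-to-methoxy exchange.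

The next compound, compound 4, `C#CCNC1CCc2c(SCCc3cccc(OC)c3)cccc21`, differs from compound 1 in one place: methoxy in place of bromo on an aromatic carbon.

On the numbers available, a moderate move toward stronger inhibition is expected in this assay, as the step from compound 1 to compound 4 is estimated at a 2.5-fold lower number from compound 1 to compound 4 (0.41 log units; beyond the scatter). Compound 4 is therefore expected to give about 12000 nM, within a range of 4000 nM to 40000 nM.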

Compound 4, half-maximal inhibitory concentration: 28700 nM
Compound 4: the middle estimate sits 2.4-fold (0.38 log units) below what was measured; the measured number falls inside the stated range.
By their numbers in this assay, from the lowest: compound 2; then compound 3; then compounds 4 and 1 (each within the scatter of the next).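

In this assay the exchange of 3-bromophenyl for 3-methoxyphenyl on the longer linker gives a 1.1-fold lower number from compound 1 to compound 4 (0.03 log units; within the scatter), so on this linker the two groups cannot be told apart at this position. The earlier compounds shown here could not show this: none of them paired bromo and methoxy on the same linker. No available data bear on the cause of this result.

Methoxy also appears on the shorter linker, where compound 2 gives 3190 nM against 28700 nM for compound 4, but the bromo partner of compound 2 is not among the compounds shown, so the exchange cannot be read on that linker. From the compounds shown here alone, it also remains open whether an amine or a carboxylic acid on this aromatic carbon would give a number close to those of compound 1 and compound 4.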